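Truncation of the sulfonyl side chain in the acyl sulfonamide series

The source may hold more compounds than are shown below. What is called first, only, known or untested is meant among the compounds shown, and "the series" means these compounds.

For the measured compounds named here, compound 1 `O=C(NS(=O)(=O)CCNC(=O)C1CC1)c1ccc(Nc2nc(NC3(c4ccc(Cl)cc4)CC3)nc(OCC(F)(F)F)n2)cc1` is the lower of the two measured members of the pair in a physicochemical assay for permeability, using PAMPA, at pH 7.4; a higher number here means that the compound crosses the layer faster, a lower number that the compound crosses the layer more slowly: compound 1 gives 1 nm/s, while compound 2 `CC(C)NC(=O)NCCS(=O)(=O)NC(=O)c1ccc(Nc2nc(NC3(c4ccc(Cl)cc4)CC3)nc(OCC(F)(F)F)n2)cc1` gives 45 nm/s, a 45-fold higher number from compound 1 to compound 2 (1.65 log units; beyond the scatter). Compound 3 `CS(=O)(=O)NC(=O)c1ccc(Nc2nc(NC3(c4ccc(Cl)cc4)CC3)nc(OCC(F)(F)F)n2)cc1` is not yet measured. Relative to compound 1 the change is hydrogen in place of ((cyclopropylcarbonyl)amino)methyl on a saturated chain carbon bound to a sulfonyl sulfur, which shortens the chain on the sulfonyl sulfur to methylsulfonyl and removes the one hydrogen-bond donor and one hydrogen-bond acceptor counted in the leaving group. Going by the values given here, only the step from compound 1 to compound 2 bears on this, and it touches the same chain end, though by exchange of the carbonyl substituent rather than by removal of the whole group. Given that large upward step, an upward step beyond the scatter is expected here as well, estimated as a 30-fold higher number from compound 1 to compound 3 (1.48 log units; beyond the scatter). Compound 3 is therefore estimated at 30 nm/s, within 5 nm/s to 150 nm/s.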

Compound 3, apparent permeability: 11 nm/s
Compound 3: the middle estimate sits 2.7-fold (0.44 log units) above what was measured; the measured number falls inside the stated range.
By their numbers in this assay, from the lowest: compound 1; then compound 3; then compound 2.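

In this assay, removing the whole ((cyclopropylcarbonyl)amino)methyl group and leaving methylsulfonyl still gives a large rise in the number (an 11-fold higher number from compound 1 to compound 3 (1.04 log units; beyond the scatter)), so the full chain is not needed to exceed compound 1. Removing ((isopropylcarbamoyl)amino)methyl goes the opposite way, with a modest fall (a 4.1-fold lower number from compound 2 to compound 3 (0.61 log units; beyond the scatter)), so the effect of the chain on the read-out depends on its end group, and compound 3 lies between the two chain-bearing compounds rather than at an extreme. No measurement on these compounds accounts for this opposite direction.

As far as these compounds go, whether a 2-aminoethyl or a 2-carboxyethyl chain on the sulfonyl sulfur would fall within this same range remains open. So does the result for a plain ethyl or propyl chain, which would separate chain length from the end group.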